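This account rests on a few compounds, and the source may have more. Where it says the series, first, only, none or still open, it means among the compounds named here.

Measured in a functional assay on BXPC-3 cells (Homo sapiens) for antiproliferative activity, read by MTT assay, with a stated time of 24 h; on this read-out higher numbers stand for weaker inhibition and lower numbers for stronger inhibition:
- compound 1 `CCn1c(C(=O)NCCN)ccc1C(CC)(CC)c1ccc(OCS(=O)(=O)c2ccccc2)c(C)c1`: 6430 nM
- compound 2 `CCn1c(C(=O)N[C@@H](CO)C(C)C)ccc1C(CC)(CC)c1ccc(OCS(=O)(=O)c2ccccc2)c(C)c1`: 13200 nM
- compound 3 `CCn1c(C(=O)N[C@@H](CO)CCO)ccc1C(CC)(CC)c1ccc(OCS(=O)(=O)c2ccccc2)c(C)c1`: > 50000 nM

For compound 3 the assay gives only a limit, > 50000 nM, and not a number. It sits at the weak end of this set, with an at least 7.7-fold higher number from compound 1 to compound 3 (0.89 log units; beyond the scatter) and an at least 3.7-fold higher number from compound 2 to compound 3 (0.57 log units; beyond the scatter).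

Compound 4 `CCn1c(C(=O)N[C@H](C(=O)O)C(C)C)ccc1C(CC)(CC)c1ccc(OCS(=O)(=O)c2ccccc2)c(C)c1` changes the group on the amide-type nitrogen: 1-carboxy-2-methylpropyl in place of 3-hydroxy-1-(hydroxymethyl)propyl on an amide-type nitrogen. The entering 1-carboxy-2-methylpropyl shares its isopropyl with the 1-(hydroxymethyl)-2-methylpropyl of compound 2. The closest guide is therefore an at least 3.7-fold higher number from compound 2 to compound 3 (0.57 log units; beyond the scatter), a step that replaced isopropyl with 2-hydroxyethyl. Reversing that swap points to a lower number in this assay. For the measured compounds named here, none of the measured compounds carries a carboxy group, so this step guides only in part, and a reading at the limit remains possible. A modest fall is expected, and the estimate is an at least 1.7-fold lower number from compound 3 to compound 4 (0.25 log units; that floor lies within the scatter). For compound 4 the estimated value is 28000 nM, with an expected range of 10000 nM to 50000 nM.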

Compound 4, half-maximal inhibitory concentration: 16200 nM
Estimate against measurement, compound 4: 1.7-fold (0.24 log units) above; measured number inside the range.
By their numbers in this assay, from the lowest: compound 1; then compounds 2 and 4 (each within the scatter of the next). At a limit, above all of these: compound 3.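

The 1-carboxy-2-methylpropyl group on this amide-type nitrogen gives a readable number, with an at least 3.0-fold lower number from compound 3 to compound 4 (0.48 log units; beyond the scatter). The carboxy and hydroxymethyl forms of the isopropyl-bearing group read alike, with a 1.2-fold higher number from compound 2 to compound 4 (0.09 log units; within the scatter), so a carboxy group here is tolerated as well as the alcohol of compound 2. The 2-aminoethyl group keeps the lowest number of the set, with a 2.5-fold higher number from compound 1 to compound 4 (0.40 log units; beyond the scatter).

As far as these compounds go, compound 3 stands only at a limit, > 50000 nM, so the true size of its gap to compound 4 stays open. Also open, from the compounds shown here alone, is how a methyl ester in place of the carboxylic acid, or a longer chain such as 3-aminopropyl in place of 2-aminoethyl, would read on this amide-type nitrogen.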